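The compounds below may be only part of what the source reports. "The series", "measured", "known", "first", "only" and "open" are said of these compounds alone.

Compound 1 `O=C(CCc1ccc(C(F)(F)F)cc1)Nc1ccc2nc(N3CCC3)ccc2c1` is the starting point of this small set. In a functional assay on HEK293 cells for activation of melanin-concentrating hormone receptor 1 (Rattus norvegicus), read by inositol phosphate accumulation (a lower number here means that less compound is needed, a higher number that more compound is needed for the effect), compound 1 gives 56 nM. Compound 2 `CC1CCCN1c1ccc2cc(NC(=O)CCc3ccc(C(F)(F)F)cc3)ccc2n1` gives 270 nM, the change being a 4.8-fold higher number from compound 1 to compound 2 (0.68 log units; beyond the scatter). Compound 3 `CC(C)C(=O)NC1CCN(c2ccc3cc(NC(=O)CCc4ccc(C(F)(F)F)cc4)ccc3n2)C1` gives 90 nM. The number for compound 3 is the second highest of the three: compound 1 is nearest, with a 1.6-fold higher number from compound 1 to compound 3 (0.21 log units; within the scatter), and compound 2 is furthest, with a 3.0-fold lower number from compound 2 to compound 3 (0.48 log units; beyond the scatter).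

Compound 4 `O=C(CCc1ccc(C(F)(F)F)cc1)Nc1ccc2nc(N3CCC4(CCNC4)C3)ccc2c1` has not yet been measured. It differs from compound 3 in one place: a group of 9 heavy atoms (7 carbon, 2 nitrogen; 2 five-membered non-aromatic rings with 1 hetero atom each) in place of a group of 11 heavy atoms (8 carbon, 2 nitrogen, 1 oxygen; one five-membered non-aromatic ring with 1 hetero atom), on an aromatic carbon. The measured steps that bear on this exchange are the two that vary the same substituent on the shared core, a 1.6-fold higher number from compound 1 to compound 3 (0.21 log units; within the scatter), which stayed within the scatter, and a 3.0-fold lower number from compound 2 to compound 3 (0.48 log units; beyond the scatter), which was modest. Both suggest that a change at this position moves the number only modestly. Among the compounds with values here, no measured step has yet introduced a second non-aromatic ring at this position, so the direction is not settled. For compound 4 a step of a 1.2-fold higher number from compound 3 to compound 4 (0.09 log units; within the scatter) is expected, not clearly beyond the scatter. Compound 4 is estimated at 110 nM, with a range from 35 nM to 350 nM.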

Compound 4, half-maximal effective concentration: 140 nM
Estimate against measurement, compound 4: 1.3-fold (0.10 log units) below; measured number inside the range.
By their numbers in this assay, from the lowest: compounds 1, 3, 4 and 2 (each within the scatter of the next, the first and the last beyond it).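

In this assay, a group with two five-membered non-aromatic rings on this aromatic carbon, next to the ring nitrogen, gives a 1.6-fold higher number from compound 3 to compound 4 (0.19 log units; within the scatter) in place of 3-((isopropylcarbonyl)amino)pyrrolidin-1-yl, so the exchange is not resolved from that amide-bearing group. Against 2-methylpyrrolidin-1-yl it gives a 1.9-fold lower number from compound 2 to compound 4 (0.29 log units; within the scatter), again unresolved, while against azetidin-1-yl it gives a 2.5-fold higher number from compound 1 to compound 4 (0.40 log units; beyond the scatter), the only one of these three steps that clears the scatter. No measurement at hand accounts for any of these steps.

Still open, on these data alone, is whether an acetyl or methyl group on the free ring nitrogen of the entering group would shift the number. Equally open, as far as these compounds go, is how a six-membered ring such as morpholin-4-yl or piperazin-1-yl would compare at this position.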